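A few compounds are considered here, and "the series" means these few. Any claim that something is new, unique, unknown or untested is made for them only; others in the source may bear on it.

The following were measured in a functional assay on NCI-H1975 cells (Homo sapiens) for inhibition, read by MTT assay, with a stated time of 72 h; on this read-out higher numbers stand for weaker inhibition and lower numbers for stronger inhibition:

compound 1 `CCOc1cc2ncnc(Nc3ccc(F)c(Cl)c3)c2cc1OC(=O)CCl`, 60 nM
compound 2 `CCOc1cc2ncnc(Nc3ccc(F)c(Cl)c3)c2cc1OC(=O)CSc1nnnn1C`, 2100 nM
compound 3 `CCOc1cc2ncnc(Nc3ccc(F)c(Cl)c3)c2cc1OC(=O)CSc1nccn1C`, 6900 nM

Compound 3 gives the highest number of the three in this assay, separated from compound 2 by a 3.3-fold higher number from compound 2 to compound 3 (0.52 log units; beyond the scatter) and from compound 1 by a 120-fold higher number from compound 1 to compound 3 (2.06 log units; beyond the scatter). Compound 4 `CCOc1cc2ncnc(Nc3ccc(F)c(Cl)c3)c2cc1OC(=O)CSc1nc2ccccc2n1C` differs from compound 3 in one place: 1-methyl-1H-benzimidazol-2-yl in place of 1-methyl-1H-imidazol-2-yl on a sulfur. For the measured compounds named here, no measured step bears directly on fusing a six-membered carbon ring onto the five-membered ring; the steps that come closest are the replacement of chloro by a heteroaryl sulfanyl group, a 35-fold higher number from compound 1 to compound 2 (1.54 log units; beyond the scatter) and a 120-fold higher number from compound 1 to compound 3 (2.06 log units; beyond the scatter), and the exchange of one five-membered heteroaryl for another on the sulfur, a 3.3-fold higher number from compound 2 to compound 3 (0.52 log units; beyond the scatter). Both sulfanyl compounds sit far from compound 1, and the modest gap between them suggests the identity of the heteroaryl matters less than its presence. Compound 4 is therefore expected to remain near compound 3, with a step of a 1.2-fold lower number from compound 3 to compound 4 (0.06 log units; within the scatter), which is within the scatter. The estimate for compound 4 in this assay is 6000 nM, with a range from 2000 nM to 20000 nM.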

Compound 4, half-maximal inhibitory concentration: 9100 nM
Beside the measured number, compound 4's estimate is 1.5-fold (0.18 log units) below it, within the range that was stated.
By their numbers in this assay, from the lowest: compound 1; then compound 2; then compounds 3 and 4 (each within the scatter of the next).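

In this assay, 1-methyl-1H-benzimidazol-2-yl on the sulfur reads the same as 1-methyl-1H-imidazol-2-yl within the scatter (a 1.3-fold higher number from compound 3 to compound 4 (0.12 log units; within the scatter)), so this position accepts the additional six-membered aromatic ring of carbon only without a step beyond the scatter. The larger group keeps the modest distance from the tetrazolyl compound (a 4.3-fold higher number from compound 2 to compound 4 (0.64 log units; beyond the scatter)) and the large distance from the chloro compound (a 150-fold higher number from compound 1 to compound 4 (2.18 log units; beyond the scatter)), so all three heteroaryl sulfanyl groups shown stand far from chloro on the saturated chain carbon. The data offer no explanation for any of these steps.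

Still open, as far as these compounds go, is whether a morpholine or a piperidine on that chain carbon, with no sulfur, would stand as far from compound 1. Also open, from the compounds shown here alone, is how a longer chain between the carbonyl and the sulfur would read.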